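A few compounds are considered here, and "the series" means these few. Any claim that something is new, unique, unknown or untested is made for them only; others in the source may bear on it.

Compound 1 `C=CCN1CCN(CC(=O)NC2(c3ccc(Cl)c(Cl)c3)C(=O)Nc3cc(Cl)cc(Cl)c32)CC1` — 38 nM
Compound 2 `CCN1CCN(CC(=O)NC2(c3ccc(Cl)cc3)C(=O)Nc3cc(Cl)c(C)cc32)CC1` — 129 nM

In an in vitro functional assay on CHO-CREluc cells for antagonist activity at growth hormone secretagogue receptor type 1 (Homo sapiens), read by a luciferase reporter, with a stated time of 4 h (on this read-out lower numbers stand for stronger inhibition and higher numbers for weaker inhibition), compound 1 gives 38 nM, the lower of the two measured numbers. Compound 2 gives 129 nM, a higher number beyond the usual scatter; since these two structures differ in more than one place, their values alone cannot be traced to any single change. Compound 3 `CCN1CCN(CC(=O)NC2(c3ccc(Cl)c(Cl)c3)C(=O)Nc3cc(Cl)cc(Cl)c32)CC1` is reached from compound 1 by methyl in place of vinyl on a saturated chain carbon bound to an amine nitrogen in a ring. A change this small is expected to alter inhibition only modestly, if at all, most likely within the scatter; the expected step is a 1.4-fold higher number from compound 1 to compound 3 (0.16 log units; within the scatter). Compound 3 is therefore estimated at 55 nM, within a range of 20 nM to 150 nM.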

Compound 3, half-maximal inhibitory concentration: 7 nM
Estimate against measurement, compound 3: 7.9-fold (0.90 log units) above; the whole stated range lies above it.
By their numbers in this assay, from the lowest: compound 3; then compound 1; then compound 2.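

Going from 4-allylpiperazin-1-yl to 4-ethylpiperazin-1-yl brings a 5.4-fold lower number from compound 1 to compound 3 (0.73 log units; beyond the scatter) and so shows that this end of the molecule matters: with the rest of the structure unchanged, a small change to the chain shifts inhibition beyond the usual scatter. Compound 2 could not show this, as it differs from compound 1 in more than one place. Nothing measured here explains the shift.

Still open, from the compounds shown here alone, is whether a propyl or a hydroxyethyl chain in the same place would give a lower or a higher number. Going by these compounds, whether ethyl brings a similar gain on the core of compound 2 is also open.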